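This account rests on a few compounds, and the source may have more. Where it says the series, first, only, none or still open, it means among the compounds named here.

Measured compounds:
- compound 1: `CCOC(=O)/C=C/C(=O)N(CC(N)=O)NC(=O)[C@@H]1CCCN1C(C)=O`, 8.3 nM in an assay on isolated protein for inhibition of legumain (Mus musculus), read by fluorescence, with stated times of 30 s and 2.5 h; a lower number here means a stronger inhibitor, a higher number a weaker inhibitor
- compound 2: `CCOC(=O)/C=C/C(=O)N(CC(N)=O)NC(=O)[C@@H]1CCCN1C(=O)C(C)(C)NC(C)=O`, 198 nM in this assay

Among the measured compounds shown here, compound 2 holds the highest of the two numbers so far; its nearest neighbour is compound 1, and the single measured step, a 24-fold higher number from compound 1 to compound 2 (1.38 log units; beyond the scatter), is large and beyond the scatter. For the measured compounds named here, that step is the only one that changes the group on the carbonyl carbon attached to the ring nitrogen of the shared core.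

Compound 3, `CCOC(=O)/C=C/C(=O)N(CC(N)=O)NC(=O)[C@@H]1CCCN1C(=O)c1cccc(NC(C)=O)c1`, is to be measured in this assay. It differs from compound 2 by 3-acetamidophenyl in place of 1-acetamido-1-methylethyl on a carbonyl carbon. Going by the values given here, no measured pair covers this exchange directly; the step from compound 1 to compound 2 shows only that the substituent at this carbonyl carbon can move the number far, with the acetamido-bearing group giving the weaker result. Since the acetamide is kept and only its carrier changes, the expectation for compound 3 is a number near that of compound 2 or somewhat lower, with wide uncertainty, the expected step being a 1.7-fold lower number from compound 2 to compound 3 (0.22 log units; within the scatter). The estimate for compound 3 is 120 nM, within 25 nM to 600 nM.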

Compound 3, half-maximal inhibitory concentration: > 1000 nM
Compound 3 ended at the assay's limit; the forecaster's own chance of this, stated with the estimate: 5%; at least 8.3-fold (0.92 log units) between middle value and limit.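

In this assay compound 3 returns a limit and not a number: the limit of > 1000 nM in this assay, at which 1 of the 3 values shown sits. With the acetamide kept, the carrier alone changes the outcome on a carbonyl carbon whose other neighbours are amide-type nitrogen in a ring: 3-acetamidophenyl in place of 1-acetamido-1-methylethyl gives an at least 5.0-fold higher number from compound 2 to compound 3 (0.70 log units; beyond the scatter), so the acetamido group does not fix the number at this position by itself. Set against the methyl group, 3-acetamidophenyl gives an at least 120-fold higher number from compound 1 to compound 3 (2.08 log units; beyond the scatter), and both acetamido-bearing groups, in compound 2 and compound 3, now sit on the weaker side of compound 1, with no compound shown going against this.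

The compounds shown leave open whether the aromatic ring or the acetamide on it accounts for the result, a question that a plain phenyl group on this carbonyl carbon, or a phenyl group carrying an amine or a carboxylic acid in place of the acetamide, would address. On these data alone, how far compound 3 lies past its limit also stays unknown, so both of its steps give only a lower bound on their true size.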